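Chain branching at the amide: compound 2 to compound 3

This account rests on a few compounds, and the source may have more. Where it says the series, first, only, none or still open, it means among the compounds named here.

In a functional assay on MCF7 cells (Homo sapiens) for antiproliferative activity, read by sulforhodamine B assay, with a stated time of 48 h (on this read-out lower numbers stand for stronger inhibition and higher numbers for weaker inhibition), compound 1 `CCC(=O)Nc1ccc(S(=O)(=O)Oc2ccccc2C(C)C)cc1` gives 11000 nM and compound 2 `CCCCCC(=O)Nc1ccc(S(=O)(=O)Oc2ccccc2C(C)C)cc1` gives 5300 nM, the lower of the two numbers. Among the measured compounds shown here, the one step in hand, a 2.1-fold lower number from compound 1 to compound 2 (0.32 log units; beyond the scatter), shows a longer chain on the carbonyl carbon going with a lower number. For the measured compounds named here, compound 3 `CC(C)c1ccccc1OS(=O)(=O)c1ccc(NC(=O)C(C)(C)C)cc1` carries the change (tert-butyl in place of pentyl on a carbonyl carbon), which removes one chain carbon and adds branching; no step here tests branching. Compound 3 is therefore expected to sit somewhat back toward compound 1, a step of a 1.5-fold higher number from compound 2 to compound 3 (0.18 log units; within the scatter), and its estimate in this assay is 8000 nM, between 4000 nM and 16000 nM.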

Compound 3, half-maximal inhibitory concentration: 6500 nM
Estimate against measurement, compound 3: 1.2-fold (0.09 log units) above; the measured number falls inside the stated range.
By their numbers in this assay, from the lowest: compounds 2, 3 and 1 (each within the scatter of the next, the first and the last beyond it).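

In this assay, tert-butyl on the carbonyl carbon cannot be told apart from pentyl (a 1.2-fold higher number from compound 2 to compound 3 (0.09 log units; within the scatter)) or from ethyl (a 1.7-fold lower number from compound 1 to compound 3 (0.23 log units; within the scatter)), even though compound 1 and compound 2 stand apart beyond the scatter. Branching at this position therefore gives no readable gain or loss against either straight chain. Nothing on hand explains this result. Still open, on these data alone, is how a longer chain such as octyl, or a ring such as cyclohexyl or phenyl, would read on the same carbonyl carbon.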